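The compounds below may be only part of what the source reports. "The series", "measured", "known", "first", "only" and "open" are said of these compounds alone.

Measured so far in a functional assay on Jurkat cells (Homo sapiens) for antiproliferative activity, read by MTT assay; on this read-out higher numbers stand for weaker inhibition and lower numbers for stronger inhibition
- compound 1 `COc1ccccc1/C=C1\CCc2cc(OC)c(OC)cc2C1=O` gives > 50000 nM (a limit, not a number)
- compound 2 `COc1cccc(/C=C2\CCc3cc(OC)c(OC)cc3C2=O)c1` gives 5000 nM
- compound 3 `COc1cc2c(cc1OC)C(=O)/C(=C/c1cccc(Cl)c1)CC2` gives 9000 nM

The reading for compound 1 is only a limit, (the limit of > 50000 nM in this assay, at which 1 of the 3 values shown sits), and not a number. Compound 4 `COc1cc2c(cc1OC)C(=O)/C(=C/c1cccc(C)c1)CC2` is still unmeasured. It carries 3-methylphenyl in place of 2-methoxyphenyl on a double-bonded chain carbon bound to a double-bonded ring carbon, and the difference counts as 3-methylphenyl in place of 2-methoxyphenyl on a double-bonded chain carbon bound to a double-bonded ring carbon.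

Among the measured compounds shown here, two measured steps bear on this change, since each also replaces 2-methoxyphenyl at that place: an at least 10-fold lower number from compound 1 to compound 2 (1.00 log units; beyond the scatter) with 3-methoxyphenyl, and an at least 5.5-fold lower number from compound 1 to compound 3 (0.74 log units; beyond the scatter) with 3-chlorophenyl. Between those two products, a 1.8-fold higher number from compound 2 to compound 3 (0.26 log units; within the scatter) stays within the scatter, so the two replacements read alike. A step of similar size is therefore expected for 3-methylphenyl, toward a lower number and stronger inhibition. The expected step is an at least 7.1-fold lower number from compound 1 to compound 4 (0.85 log units; beyond the scatter) in this assay. For compound 4 the estimate is 7000 nM, with an expected range of 2500 nM to 25000 nM.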

Compound 4, half-maximal inhibitory concentration: 17000 nM
The estimate for compound 4 lay 2.4-fold (0.39 log units) below the measured number; measured number inside the range.
By their numbers in this assay, from the lowest: compounds 2, 3 and 4 (each within the scatter of the next, the first and the last beyond it). At a limit, above all of these: compound 1.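

In this assay, 3-methylphenyl also improves on 2-methoxyphenyl at this place, an at least 2.9-fold lower number from compound 1 to compound 4 (0.46 log units; beyond the scatter), so a third replacement goes the same way, and this one has no hydrogen-bond acceptor. As far as these compounds go, the size of that step stays open on one side, since compound 1 stands only at a limit: the limit of > 50000 nM in this assay, at which 1 of the 4 values shown sits. Among the replacements, the first separation appears: a 3.4-fold higher number from compound 2 to compound 4 (0.53 log units; beyond the scatter), whereas a 1.9-fold higher number from compound 3 to compound 4 (0.28 log units; within the scatter), so 3-methoxyphenyl and 3-methylphenyl now read apart while 3-chlorophenyl reads alike with each.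

From the compounds shown here alone, it remains open whether 2-chlorophenyl or 2-methylphenyl would stay as weak as compound 1, which would tie the loss to the place and not to the methoxy group. Also open, going by these compounds, is how a 3-aminophenyl, a 3-carboxyphenyl or a longer 3-ethoxyphenyl group would read at this place.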